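The compounds below may be only part of what the source reports. "The series", "measured", "known", "first", "only" and "open" are said of these compounds alone.

Series so far, in a functional assay on MDA-MB-231 cells (Homo sapiens) for cytotoxicity, read by MTT assay, with a stated time of 24 h; a higher number here means a weaker inhibitor, a lower number a stronger inhibitor:
Compound 1 `CCOC(=O)/C=C/c1ccc(O)c(/C(=C/c2ccc(O)cc2)C(=O)OCC)c1` gives 15000 nM
Compound 2 `CCOC(=O)C(=C\c1ccc(OC)c(OC)c1)/C(=C/c1ccc(OC)c(OC)c1)C(=O)OCC` gives "not determined" (no result reported)

Among the measured compounds shown here, compound 1 holds the only number, so it cannot yet be ranked against anything, and compound 2 offers no comparison. Compound 3 `CCOC(=O)/C=C/c1ccc(O)c(/C(=C/c2ccc(OC(C)=O)cc2)C(=O)OCC)c1` differs from compound 1 by acetyl in place of hydrogen on an oxygen on an aromatic ring with acetyl in place of hydrogen on an oxygen on an aromatic ring. For the measured compounds named here, no measured step shows what this change does, so no step beyond the scatter is expected in this assay in either direction. The estimated 1.2-fold lower number from compound 1 to compound 3 (0.06 log units; within the scatter) is correspondingly small. For compound 3 the expected value is 13000 nM within an estimated range of 4500 nM to 35000 nM for now.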

Compound 3, half-maximal inhibitory concentration: 16000 nM
Compound 3: the middle estimate sits 1.2-fold (0.09 log units) below what was measured, and the stated range covers the measured number.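

In this assay, the change from 4-hydroxyphenyl to 4-acetoxyphenyl gives a 1.1-fold higher number from compound 1 to compound 3 (0.03 log units; within the scatter) and so leaves the read-out within the scatter. For this pair, the free hydroxy at this position is therefore not needed to keep the cytotoxicity seen with compound 1. No supporting measurement bears on this result.

From the compounds shown here alone, whether a longer chain than acetyl on this oxygen, or an amine in its place, would move the number remains open. The effect of the same change at the second hydroxy of the shared core is also unknown.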